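A few compounds are considered here, and "the series" means these few. Any claim that something is new, unique, unknown or untested is made for them only; others in the source may bear on it.

Measured so far in an assay on HEK293 cells for displacement of a labelled ligand from Melanocortin receptor 4 (Homo sapiens); a higher number here means a weaker inhibitor, a lower number a stronger inhibitor:
- compound 1, `CC(C)C[C@H](N)c1cc(C(F)(F)F)ccc1N1CCN(C(=O)CCc2c(Cl)cccc2Cl)CC1`: 2600 nM
- compound 2, `CC(C)C[C@H](N)c1cc(C(F)(F)F)ccc1N1CCN(C(=O)CCc2cccs2)CC1`: 4600 nM

Compound 2 holds the higher of the two numbers in this assay, though its gap to compound 1, a 1.8-fold higher number from compound 1 to compound 2 (0.25 log units; within the scatter), lies within the scatter, so the two are not told apart. Compound 3, `CC(C)C[C@H](N)c1cc(C(F)(F)F)ccc1N1CCN(C(=O)CCc2cn(C)c3ccccc23)CC1`, carries the same core and the same amide-linked chain, with the difference (1-methyl-1H-indol-3-yl in place of thiophen-2-yl on a saturated chain carbon, two bonds along the chain from a carbonyl carbon).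

For the measured compounds named here, only one measured step bears on this place in the chain, the exchange of the aryl group on the saturated chain carbon from compound 1 to compound 2, a 1.8-fold higher number from compound 1 to compound 2 (0.25 log units; within the scatter), and that step did not move the number beyond the scatter. The aryl groups seen so far differ in size and ring count without a read-out difference of note, so the entry of the larger 1-methyl-1H-indol-3-yl group gives no basis for predicting a direction. The expected step from compound 2 to compound 3 is therefore small, a 1.5-fold lower number from compound 2 to compound 3 (0.19 log units; within the scatter), landing near the two measured values. For compound 3 the estimate in this assay is 3000 nM, with a range from 900 nM to 10000 nM.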

Compound 3, inhibition constant: 3000 nM
Beside the measured number, compound 3's estimate shows no gap at the digits printed; measured number inside the range.
By their numbers in this assay, from the lowest: compounds 1, 3 and 2 (each within the scatter of the next).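

In this assay the exchange of thiophen-2-yl for 1-methyl-1H-indol-3-yl on a saturated chain carbon, two bonds along the chain from a carbonyl carbon, gives a 1.5-fold lower number from compound 2 to compound 3 (0.19 log units; within the scatter) and the exchange of 2,6-dichlorophenyl for the same group gives a 1.2-fold higher number from compound 1 to compound 3 (0.06 log units; within the scatter) in this series. Compound 3 thus adds a case the earlier pair did not cover: a group with a five-membered aromatic ring and a six-membered aromatic ring of carbon only, which stays within the scatter of both compound 1 and compound 2, so the three aromatic groups at this place are not told apart. Nothing at hand offers an explanation for this lack of separation.

The compounds shown leave open whether any group at this place can move the number beyond the scatter, as all three carry an aromatic ring there. A primary amine, a carboxylic acid or a cyclohexyl group in that place would test this, as would a longer chain between the carbonyl and the ring.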